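The compounds below may be only part of what the source reports. "The series", "measured", "known", "first", "only" and "open" are said of these compounds alone.

Measured in a functional assay on HepG2 cells (Homo sapiens) for antiproliferative activity, read by MTT assay, with a stated time of 48 h; on this read-out lower numbers stand for stronger inhibition and higher numbers for weaker inhibition:
- compound 1 `CCCCc1ccc2c(c1)C(=O)C(=O)N2`: > 10000 nM
- compound 2 `O=C1Nc2ccc(-c3ccc(C(F)(F)F)cc3)cc2C1=O`: 5430 nM
- compound 3 `C=CCN1C(=O)C(=O)c2cc(-c3ccc(OC)cc3)ccc21`: 7090 nM

Compound 1 gives > 10000 nM, which is a limit of the assay and not a number. Compound 2 at 5430 nM and compound 3 at 7090 nM lie within the scatter of each other, so this assay does not separate these two compounds. They also differ in more than one place, so neither value isolates the effect of a single change.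

The next compound is compound 4 `COc1ccc(-c2ccc3c(c2)C(=O)C(=O)N3Cc2cccc(Cl)c2)cc1`. It replaces the allyl of compound 3 with 3-chlorobenzyl, on a saturated chain carbon bound to an amide-type nitrogen in a ring: 3-chlorophenyl in place of vinyl on a saturated chain carbon bound to an amide-type nitrogen in a ring. For the measured compounds named here, no measured pair tests a change at this place, so the expectation is tentative. With compound 3 at 7090 nM, a modest step toward stronger inhibition, somewhat beyond the scatter, is expected. The expected step is a 3.9-fold lower number from compound 3 to compound 4 (0.60 log units; beyond the scatter). For compound 4 the estimated value is 1800 nM, with an expected range of 400 nM to 6000 nM.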

Compound 4, half-maximal inhibitory concentration: 320 nM
For compound 4 the middle estimate is 5.6-fold (0.75 log units) above the measured one; the measured number lies below the stated range.
By their numbers in this assay, from the lowest: compound 4; then compounds 2 and 3 (each within the scatter of the next). At a limit, above all of these: compound 1.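

In this assay, for the compounds shown here, the change from allyl to 3-chlorobenzyl gives a 22-fold lower number from compound 3 to compound 4 (1.35 log units; beyond the scatter) and is the first single change whose effect can be read. It shows that the group on a saturated chain carbon bound to an amide-type nitrogen in a ring can move this read-out well beyond the scatter, with no hydrogen-bond donor or acceptor entering. Going by these compounds alone, nothing measured so far accounts for the size of this step.

Going by these compounds, whether the step comes from the aromatic ring or from the chlorine remains open, and unsubstituted benzyl would separate the two. Also open, on these data alone, is whether a longer chain between the nitrogen and the ring, or an amine in place of the chlorine, would keep the stronger inhibition.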